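Amino in place of fluoro in compound 3

A few compounds are considered here, and "the series" means these few. Any claim that something is new, unique, unknown or untested is made for them only; others in the source may bear on it.

Compound 1: `COc1ccc(-c2ccc3ncn(-c4cc(OC)c(OC)c(OC)c4)c3c2)cc1F`, 1430 nM
Compound 2: `COc1cc(-n2cnc3ccc(-c4cccc(F)c4)cc32)cc(OC)c1OC`, 5270 nM

For the measured compounds named here, in a functional assay on A549 cells (Homo sapiens) for antiproliferative activity, read by MTT assay, with a stated time of 72 h (on this read-out lower numbers stand for stronger inhibition and higher numbers for weaker inhibition), compound 2 gives 5270 nM, the higher of the two numbers measured so far. Going by the values given here, its only neighbour on this scale is compound 1 at 1430 nM.

Compound 3 `COc1cc(-n2cnc3ccc(-c4cccc(N)c4)cc32)cc(OC)c1OC` has not yet been measured. It differs from compound 2 in one place: amino in place of fluoro on an aromatic carbon. In words, this is amino in place of fluoro on an aromatic carbon.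

Among the compounds with values here, only one measured step offers any guide, and it is an indirect one: a 3.7-fold higher number from compound 1 to compound 2 (0.57 log units; beyond the scatter). That modest step came from hydrogen in place of methoxy on an aromatic carbon, which is a different swap. Within the data shown here, no measured pair shows what replacing fluoro with amino does, so the direction remains uncertain. A step of about that size at most is expected in this assay, most likely none beyond the scatter, with a slight lean towards a lower number.

For compound 3 the estimated value is 3500 nM, with an expected range from 1000 nM to 10000 nM. This estimate means an expected 1.5-fold lower number from compound 2 to compound 3 (0.18 log units; within the scatter).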

Compound 3, half-maximal inhibitory concentration: 640 nM
Compound 3: the middle estimate sits 5.5-fold (0.74 log units) above what was measured, outside the stated range (below it).
By their numbers in this assay, from the lowest: compound 3; then compound 1; then compound 2.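

Swapping fluoro for amino on this six-membered aromatic ring of carbon only, meta to a large group, is far from a neutral change: in this assay it gives an 8.2-fold lower number from compound 2 to compound 3 (0.92 log units; beyond the scatter). For the compounds shown here, the earlier compounds showed only that this ring responds to adding or removing a methoxy group, whereas this result shows that the group at the position held by fluoro in compound 2 also matters. The 3-aminophenyl ring also outdoes the 3-fluoro-4-methoxyphenyl ring, with a 2.2-fold lower number from compound 1 to compound 3 (0.35 log units; beyond the scatter), which makes compound 3 the lowest of the three numbers even without a methoxy group on that ring, although no available measurement explains why the amino group has this effect.

On these data alone, it remains open whether the gain belongs to the amino group in particular or would also appear with a hydroxy, methylamino or acetamido group in the same place. Also unresolved is whether adding a methoxy group to compound 3, placed as in compound 1, would lower the number further, as the step between compound 1 and compound 2 might suggest, or whether the two changes would not add up.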